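The source may hold more compounds than are shown below. What is called first, only, known or untested is meant among the compounds shown, and "the series" means these compounds.

Of the compounds shown here, three of one family have been tested so far in a functional assay on A-431 cells (Homo sapiens) for cytotoxicity, read by MTT assay, with a stated time of 72 h, tested at 30 uM; on this read-out higher numbers stand for more inhibition of growth at the one concentration tested and lower numbers for less inhibition of growth. Compound 1 `N/C(=N\NC(=S)N1CCCCCC1)c1ccccn1` gives 72.3%. Compound 2 `N/C(=N\NC(=S)N1CCOCC1)c1ccccn1` gives 78.8%, and compound 3 `Cc1ccnc(/C(N)=N/NC(=S)N2CCOCC2)c1` gives 74.6%. The difference between the cores of compound 1 and compound 2 is not broken down here. From compound 2 to compound 3 the change is methyl in place of hydrogen on an aromatic carbon, and the step it made is a number 4.2 percentage points lower from compound 2 to compound 3 (within the scatter). Compound 4 `Cc1cccc(/C(N)=N/NC(=S)N2CCCCCC2)n1` is not yet measured; it differs from compound 1 by methyl in place of hydrogen on an aromatic carbon, the same kind of change, though here the methyl sits next to the ring nitrogen, whereas in compound 3 it sits opposite the ring nitrogen. For compound 4 a similarly small step is expected in this assay, namely a number 2.3 percentage points lower from compound 1 to compound 4 (within the scatter), because the earlier step of a number 4.2 percentage points lower from compound 2 to compound 3 (within the scatter) stayed within the scatter. Compound 4 is therefore estimated at 70%, somewhere between 58% and 82%.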

Compound 4, percent growth inhibition at one concentration: 63.5%
For compound 4 the middle estimate is 6.5 percentage points above the measured one, within the range that was stated.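

In this assay, the new step is a number 8.8 percentage points lower from compound 1 to compound 4 (within the scatter), and it agrees with the earlier step: the same change on two cores in this assay, a number 4.2 percentage points lower (within the scatter) from compound 2 to compound 3 and a number 8.8 percentage points lower (within the scatter) from compound 1 to compound 4, 4.6 percentage points apart, within the scatter of two such steps. On these two cores, then, methyl in place of hydrogen on an aromatic carbon leaves the number within the scatter of its partner, and the change carries over from one core to the other without a visible difference. This does not show that the methyl's position is unimportant, as the two steps differ in both core and position, and two steps at one concentration cannot exclude a small real effect.

The compounds shown leave open whether an ethyl, an amine or a carboxylic acid on the same aromatic carbon would give a step beyond the scatter. They also leave open what the methyl placed as in compound 4 would do on the core of compound 2.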